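The source may hold more compounds than are shown below. What is called first, only, known or untested is meant among the compounds shown, and "the series" means these compounds.

Of the compounds shown here, two of a shared core have been measured in an assay for inhibition of Amine oxidase [flavin-containing] B (Rattus norvegicus); on this read-out lower numbers stand for stronger inhibition and higher numbers for weaker inhibition. Compound 1 `NC(=O)[C@H](CO)Nc1cc(=O)oc2cc(OCc3cccc(Cl)c3)ccc12` gives 2400 nM in this assay. Compound 2 `NC(=O)Cc1cc(=O)oc2cc(OCc3ccccc3)ccc12` gives 200 nM in this assay. Of the two numbers, compound 2 has the lower one, and the number of compound 1 lies well beyond the usual scatter away from it; compound 1 and compound 2 differ in more than one place, so no single change accounts for that gap. Compound 3 `NC(=O)Cc1cc(=O)oc2cc(OCc3cccc(Cl)c3)ccc12` has not yet been measured in this assay. It differs from compound 2 by chloro in place of hydrogen on an aromatic carbon. Within the data shown here, no pair of measured compounds shows this change on its own, so there is no direct guide to its size. The step from compound 2 to compound 3 is expected to be small, a 1.3-fold lower number from compound 2 to compound 3 (0.12 log units; within the scatter), within or close to the scatter. Compound 3 is therefore estimated at 150 nM in this assay, with a range from 40 nM to 600 nM.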

Compound 3, half-maximal inhibitory concentration: 30 nM
Compound 3: middle estimate off by 5.0-fold (0.70 log units), on the high side; the measured number lies below the stated range.
By their numbers in this assay, from the lowest: compound 3; then compound 2; then compound 1.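

In this assay, one chlorine atom on the benzyl group matters: going from benzyl to 3-chlorobenzyl brings a 6.7-fold lower number from compound 2 to compound 3 (0.82 log units; beyond the scatter) and shows that this place on the aromatic ring responds to a change of even one heavy atom. With the chloro group held constant, the side chain on the core can now be read on its own, and carbamoylmethyl in place of (1-carbamoyl-2-hydroxyethyl)amino brings an 80-fold lower number from compound 1 to compound 3 (1.90 log units; beyond the scatter) as a step of greater size than the chloro step. No measurement available here gives a reason for either step.

As far as these compounds go, it remains open whether the gain is specific to chloro, or whether fluoro, bromo or methyl at the same place would give a similar number. From the compounds shown here alone, it is also open how a carboxylic acid or a longer chain would compare with carbamoylmethyl.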